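Thiazolidinedione series: para substituent on the terminal phenyl

A few compounds are considered here, and "the series" means these few. Any claim that something is new, unique, unknown or untested is made for them only; others in the source may bear on it.

Measured so far in a functional assay on the whole organism (strain Wistar) with Rattus norvegicus as the target, with a stated time of 15 days, at a dose of 10 mg/kg by the oral route; a higher number here means a stronger effect of the compound at the dose given, a lower number a weaker effect:
compound 1 `O=C1NC(=O)/C(=C/c2ccc(OCCSc3nnc(-c4ccccc4)[nH]3)cc2)S1` gives 19.2%
compound 2 `O=C1NC(=O)/C(=C/c2ccc(OCCSc3nnc(-c4ccc(Cl)cc4)[nH]3)cc2)S1` gives 24.6%
compound 3 `O=C1NC(=O)/C(=C/c2ccc(OCCSc3nnc(-c4ccc(Br)cc4)[nH]3)cc2)S1` gives 26.9%

The three measured compounds share one core and differ only in the substituent on the terminal phenyl. Compound 3 gives the largest of the three numbers, but both steps to it, a number 7.7 percentage points higher from compound 1 to compound 3 (within the scatter) and a number 2.3 percentage points higher from compound 2 to compound 3 (within the scatter), are within the scatter, as is a number 5.4 percentage points higher from compound 1 to compound 2 (within the scatter); the three numbers therefore sit together and no order among them can be read from this assay.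

Compound 4 `COc1ccc(-c2nnc(SCCOc3ccc(/C=C4\SC(=O)NC4=O)cc3)[nH]2)cc1` is not yet measured. Its change from compound 3 is methoxy in place of bromo on an aromatic carbon. The measured steps that touch the same position are the two that introduce bromo, a number 7.7 percentage points higher from compound 1 to compound 3 (within the scatter) and a number 2.3 percentage points higher from compound 2 to compound 3 (within the scatter), and neither moved beyond the scatter. Within the data shown here, no measured step brings in methoxy or any other oxygen-bearing group at this position, so nothing points to a change of a size that would leave the scatter.

For compound 4 the expectation in this assay is therefore a number close to that of compound 3, with an estimated step of a number 4.9 percentage points lower from compound 3 to compound 4 (within the scatter) that stays within the scatter. The estimate for compound 4 is 22%, ranging from 10% to 34%.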

Compound 4, a percentage reported as activity, at one dose (the size of the read-out at that dose, not a potency): 42.6%
Compound 4: middle estimate off by 20.6 percentage points, on the low side; the whole stated range lies below it.
By their numbers in this assay, from the lowest: compounds 1, 2 and 3 (each within the scatter of the next); then compound 4.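

In this assay this position turns out to be able to move the read-out: the step is a number 15.7 percentage points higher from compound 3 to compound 4 (beyond the scatter) and likewise a number 18 percentage points higher from compound 2 to compound 4 (beyond the scatter) and a number 23.4 percentage points higher from compound 1 to compound 4 (beyond the scatter), all three beyond the scatter, while the steps among the hydrogen, chloro and bromo compounds stayed within it. Of the four terminal phenyl groups, only the 4-methoxyphenyl separates from the others, and the exchange of bromo for methoxy adds one hydrogen-bond acceptor, a matter of counting that is not established as the source of the step. Nothing at hand bears on why this change gives a step of this size.

Open, as far as these compounds go, is whether the step belongs to methoxy itself or would extend to other oxygen-bearing groups, and a hydroxy group or an ethoxy group at the same place would separate these readings, with an amine such as dimethylamino testing whether oxygen is needed at all. Also open, from the compounds shown here alone, is whether the stronger effect would hold at other doses, as the read-out gives the size of the effect at the one dose tested only.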